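The source may report more compounds than this note shows. Statements on the series, on what has been measured and on what is new or still open speak of the compounds shown alone.

Measured so far in an ADME assay on BaF3 cells (Mus musculus) for cytotoxicity; on this read-out higher numbers stand for an effect only at larger amounts of compound and lower numbers for an effect already at smaller amounts:
- compound 1 `COC(=O)c1cc2c(Nc3ccc(OC(F)(F)F)cc3)ncnc2s1`: > 10000 nM, a limit of the assay
- compound 2 `CC(C)(C)n1ncc2c(Nc3ccc(OC(F)(F)F)cc3)ncnc21`: 7300 nM
- compound 3 `CCNC(=O)c1cc2c(Nc3ccc(OC(F)(F)F)cc3)ncnc2s1`: > 10000 nM, a limit of the assay

Compound 3 thus stands at a limit, not at a number. In this assay compound 1 also gives only a limit. Compound 4 `O=C(c1cc2c(Nc3ccc(OC(F)(F)F)cc3)ncnc2s1)N1CCC(O)CC1` differs from compound 3 by 4-hydroxypiperidin-1-yl in place of ethylamino on a carbonyl carbon. For the measured compounds named here, the one measured step at this carbonyl carbon, a step that the two limits leave unreadable from compound 1 to compound 3, gives no size because both of its ends sit at the limit of > 10000 nM in this assay, at which 2 of the 3 values shown sit. Going by the values given here, no measured step therefore shows a direction for the change to compound 4. The expectation is that compound 4 stays near the limit, with a step that the limit leaves unreadable from compound 3 to compound 4 expected to be none beyond the scatter. Compound 4 is estimated at 15000 nM, in the range 6000 nM to 40000 nM.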

Compound 4, half-maximal effective concentration: > 10000 nM
Compound 4 gave a limit, no number; the forecaster's own chance of this, stated with the estimate: 75%; the middle value does not contradict the limit.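

In this assay no step can be read among compound 1, compound 3 and compound 4, as all three give only a limit: the limit of > 10000 nM in this assay, at which 3 of the 4 values shown sit.

The compounds shown leave open whether the group on the carbonyl carbon changes the read-out in this assay at all.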